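Cytotoxicity notes: cyclohexylamino replacing the carbamoyl group

The compounds below may be only part of what the source reports. "The series", "measured", "known", "first", "only" and "open" are said of these compounds alone.

Of the compounds shown here, two have been tested in an ADME assay on HEp-2 cells (Homo sapiens) for cytotoxicity, read by CCK-8 assay, with a stated time of 6 days; on this read-out higher numbers stand for lower toxicity in this test and lower numbers for higher toxicity in this test. For the measured compounds named here, compound 1 `O=c1n(Cc2nc3cc(C(F)(F)F)ccn3c2CCCCO)c2cnccc2n1C1CC1` is the first. In this assay compound 1 gives > 100000 nM, which is a limit of the assay and not a number. Compound 2 `CS(=O)(=O)CCNC(=O)c1c(Cn2c(=O)n(C3CC3)c3ccncc32)nc2cc(Cl)ccn12` is the second. In this assay compound 2 gives > 100000 nM, again a limit rather than a measured number. Compound 2 therefore stands at the limit of > 100000 nM in this assay, at which 2 of the 2 values shown sit; on the numbers shown nothing separates the two compounds, and no step between them can be sized.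

Compound 3 `O=c1n(Cc2nc3cc(Cl)ccn3c2NC2CCCCC2)c2cnccc2n1C1CC1` has not yet been measured. It differs from compound 2 by cyclohexylamino in place of (2-(methylsulfonyl)ethyl)carbamoyl on an aromatic carbon. Going by the values given here, no measured step in this assay is available to carry over, so the expectation rests on the two limits alone. The step from compound 2 to compound 3 is expected to be an at least 1.2-fold lower number from compound 2 to compound 3 (0.09 log units; that floor lies within the scatter), which means none beyond the scatter. Compound 3 is estimated at 80000 nM, within a range from 25000 nM to 200000 nM, and the result is expected most likely to be reported again only as a limit.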

Compound 3, half-maximal cytotoxic concentration: > 100000 nM
Compound 3: only a limit was reported; the forecaster's own chance of this, stated with the estimate: 60%; at least 1.2-fold (0.09 log units) between middle value and limit.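

Compound 3 is reported in this assay as > 100000 nM and this is a limit, not a number. No step can be read between compound 2 and compound 3, since both stand only as limits: the limit of > 100000 nM in this assay, at which 3 of the 3 values shown sit. The compounds shown leave open where any of them would fall as a number, and whether cyclohexylamino in place of (2-(methylsulfonyl)ethyl)carbamoyl alters the read-out at all.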